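The source may hold more compounds than are shown below. What is called first, only, known or untested is meant among the compounds shown, and "the series" means these compounds.

For the measured compounds named here, compound 2 `CCCC[C@@H](Nc1nc(N)nc2cccnc12)C(N)=O` carries a primary amide on the shared core; in an assay on tissue (PBMC cells) for agonist activity at Toll-like receptor 8 (Homo sapiens), with a stated time of 24 h (a higher number here means that more compound is needed for the effect, a lower number that less compound is needed), compound 2 gives 36000 nM, the only number among the values shown. Compound 1 `CCCC[C@@H](Nc1nc(N)nc2cccnc12)C(=O)O` bears the acid instead; in this assay compound 1 reaches only the limit > 50000 nM. Going by the values given here, the single measured step, an at least 1.3-fold lower number from compound 1 to compound 2 (0.14 log units; that floor lies within the scatter), concerns amino in place of hydroxy on a carbonyl carbon rather than the amide nitrogen, so it offers little guidance for compound 3 `CCCC[C@@H](Nc1nc(N)nc2cccnc12)C(=O)NC`, which differs from compound 2 by methyl in place of hydrogen on an amide-type nitrogen. Compound 3 is therefore expected to give 30000 nM in this assay, between 8000 nM and 100000 nM, a step of a 1.2-fold lower number from compound 2 to compound 3 (0.08 log units; within the scatter) within the scatter.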

Compound 3, half-maximal effective concentration: > 50000 nM
Compound 3 was reported as a limit; the forecaster's own chance of this, stated with the estimate: 30%; middle value at least 1.6-fold (0.22 log units) away from the limit.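

In this assay, methyl on the amide-type nitrogen, the first change shown at this position, gives an at least 1.3-fold higher number from compound 2 to compound 3 (0.14 log units; that floor lies within the scatter), so this change brings no lower number, though the true size of the step stays unknown. The step between the acid and the methyl amide cannot be read, as both ends are limits. Compound 1 and compound 3 stop at the same limit of the assay: the limit of > 50000 nM in this assay, at which 2 of the 3 values shown sit.

As far as these compounds go, whether an ethyl group or a longer chain on this nitrogen would lower the number stays open. So does the effect of a morpholine amide at the carbonyl carbon.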